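Homologating the chain on a quinoline-isoxazole core

This account rests on a few compounds, and the source may have more. Where it says the series, first, only, none or still open, it means among the compounds named here.

Of the compounds shown here, three have been measured in a functional assay on MDA-MB-231 cells (Homo sapiens) for inhibition, read by MTT assay, with a stated time of 24 h; on this read-out lower numbers stand for stronger inhibition and higher numbers for weaker inhibition. Compound 1 `CCc1cc2ccccc2nc1-c1cc(-c2ccc(C)cc2)no1` gives only the assay limit, > 100000 nM. Compound 2 `CCCc1cc2ccccc2nc1-c1cc(-c2ccc(C)cc2)no1` likewise gives only the limit, > 100000 nM. Compound 3 `CCCCc1cc2ccccc2nc1-c1cc(-c2ccc(C(F)(F)F)cc2)no1` gives 10400 nM.

From compound 1 to compound 2 the change is methyl in place of hydrogen on a saturated chain carbon, two bonds along the chain from an aromatic carbon, and the step that the two limits leave unreadable from compound 1 to compound 2 cannot be sized because the limit of > 100000 nM in this assay, at which 2 of the 3 values shown sit, caps both values. Compound 3 carries a different core; how it differs from compound 1 is not broken down here. Compound 4 `CCCCCc1cc2ccccc2nc1-c1cc(-c2ccc(C(F)(F)F)cc2)no1` is not yet measured. It differs from compound 3 by methyl in place of hydrogen on a saturated chain carbon, four bonds along the chain from an aromatic carbon. This is the same kind of change as that from compound 1 to compound 2, but the place differs: two bonds along the chain from an aromatic carbon there, four bonds along the chain from an aromatic carbon here. Beside the unreadable earlier step, the step of a 1.2-fold lower number from compound 3 to compound 4 (0.06 log units; within the scatter) is expected to stay within the usual scatter, resting on the single readable value of compound 3, 10400 nM. Compound 4 is therefore estimated at 9000 nM, plausibly between 3000 nM and 30000 nM.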

Compound 4, half-maximal inhibitory concentration: 22100 nM
For compound 4 the middle estimate is 2.5-fold (0.39 log units) below the measured one; measured number inside the range.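

In this assay, the added methyl on the core of compound 3 comes with a 2.1-fold higher number from compound 3 to compound 4 (0.33 log units; beyond the scatter), a modest weakening that lies beyond the usual scatter. The same kind of change on the core of compound 1 sits at a different place on the chain, and its size cannot be read, as compound 1 and compound 2 both stand only at an assay limit: the limit of > 100000 nM in this assay, at which 2 of the 4 values shown sit. The result therefore shows what one added carbon does on one core, but it does not show whether the change carries over from one core to the other, in size or even in direction.

The compounds shown leave open whether a longer chain than that of compound 4, or a chain ending in an amine or a carboxylic acid, would push the number further in the same direction. They also leave open what swapping methyl for trifluoromethyl does by itself, as no pair shown differs in that one place alone.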